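Aryl swaps on the ring nitrogen: compound 4 estimate

The source may report more compounds than this note shows. Statements on the series, on what has been measured and on what is new or still open speak of the compounds shown alone.

Measured so far in an assay on isolated protein for inhibition of protein kinase C zeta type (Homo sapiens), with a stated time of 4 min, tested at 62.5 uM; on this read-out higher numbers stand for more inhibition at the one concentration tested (going by the name of the read-out) and lower numbers for less inhibition:
compound 1, `CC(C)(C)C1=NN(c2cccc(F)c2)C(c2ccc(O)cc2)C1`, 98.1%
compound 2, `CC(C)(C)C1=NN(c2ccc(F)cc2F)C(c2ccc(O)cc2)C1`, 68%
compound 3, `Cc1ccc(N2N=C(C(C)(C)C)CC2c2ccc(O)cc2)c(C)c1`, 59.9%

Compound 3 gives the lowest number of the three in this assay. Its nearest neighbour is compound 2, and the pair differ by a number 8.1 percentage points lower from compound 2 to compound 3 (within the scatter), so the two are not separated. Compound 1 stands furthest away, with a number 38.2 percentage points lower from compound 1 to compound 3 (beyond the scatter). The other measured step is a number 30.1 percentage points lower from compound 1 to compound 2 (beyond the scatter).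

Compound 4, `CC(C)(C)C1=NN(c2c(Cl)cccc2Cl)C(c2ccc(O)cc2)C1`, is not yet measured. The change from compound 3 is 2,6-dichlorophenyl in place of 2,4-dimethylphenyl on an amine nitrogen in a ring. Both prior exchanges of the group on this nitrogen moved away from compound 1, and the 2,4-difluorophenyl-to-2,4-dimethylphenyl exchange stayed within the scatter. Going by the values given here, no measured compound carries two chlorines or substituents flanking the attachment point, so the data give little guidance on direction.

Compound 4 is therefore expected to sit near compound 3, with a step of a number 4.9 percentage points lower from compound 3 to compound 4 (within the scatter) that may well stay within the scatter. The estimate for compound 4 is 55%, with a range from 30% to 80%.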

Compound 4, a percentage reported as inhibition, at one concentration (the size of the read-out at that concentration, not a potency): 65.5%
Compound 4: the middle estimate sits 10.5 percentage points below what was measured; the measured number falls inside the stated range.
By their numbers in this assay, from the lowest: compounds 3, 4 and 2 (each within the scatter of the next); then compound 1.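

In this assay, 2,6-dichlorophenyl on the amine nitrogen in the ring is not separated from the other two-substituent aryl groups (a number 5.6 percentage points higher from compound 3 to compound 4 (within the scatter); a number 2.5 percentage points lower from compound 2 to compound 4 (within the scatter)), so neither chlorine in place of methyl or fluorine nor the different substitution pattern moves the number here. The gap to 3-fluorophenyl persists (a number 32.6 percentage points lower from compound 1 to compound 4 (beyond the scatter)), leaving compound 1, the only one of the four with a single substituent on this aryl ring, apart from the other three. Nothing measured here accounts for that gap.

Still open, going by these compounds, is whether the high number belongs to 3-fluorophenyl specifically or to single-substituent aryl groups more widely, such as 3-chlorophenyl or 3-methylphenyl. The compounds shown also leave unsettled how unsubstituted phenyl, a pyridyl ring, or a methoxy or amine on the aryl ring would read on this nitrogen.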